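Notes on the step from isopropylamino to propylamino

The source may hold more compounds than are shown below. What is called first, only, known or untested is meant among the compounds shown, and "the series" means these compounds.

Measured in an ADME assay on HFF cells (Homo sapiens) for cytotoxicity, with a stated time of 8 days; a lower number here means that less compound is tolerated, a higher number that more compound is tolerated:
- compound 1 `CNc1nc(N)nc2c1ncn2/C=C1/CC1(CO)CO` gives 265000 nM
- compound 2 `CCOc1nc(N)nc2c1ncn2/C=C1/CC1(CO)CO` gives > 300000 nM as a limit
- compound 3 `CC(C)Nc1nc(N)nc2c1ncn2/C=C1/CC1(CO)CO` gives > 300000 nM as a limit

Compound 3 has no number in this assay, only the limit > 300000 nM and nothing more. That limit is shared within the series, as the limit of > 300000 nM in this assay, at which 2 of the 3 values shown sit, shows. Only compound 1 has a true number, 265000 nM, in this set.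

Compound 4 `CCCNc1nc(N)nc2c1ncn2/C=C1/CC1(CO)CO` carries propyl in place of isopropyl on a nitrogen on an aromatic ring. The closest measured change at that place is an at least 1.1-fold higher number from compound 1 to compound 3 (0.05 log units; that floor lies within the scatter), and it gives only a floor. The change at the same carbon, an at least 1.1-fold higher number from compound 1 to compound 2 (0.05 log units; that floor lies within the scatter), is likewise only a floor. The remaining comparison is a step that the two limits leave unreadable from compound 2 to compound 3 and gives no size. Going by the values given here, no measured step here therefore shows a change beyond the scatter, and the swap of isopropyl for propyl is not expected to produce one in this assay either. The estimated step is an at least 1.0-fold lower number from compound 3 to compound 4 (0.02 log units; that floor lies within the scatter), with no clear direction expected. For compound 4 the estimate is 280000 nM, with an expected range from 160000 nM to 300000 nM, and the assay may well report only a limit.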

Compound 4, half-maximal cytotoxic concentration: > 300000 nM
Compound 4 was reported as a limit; the forecaster's own chance of this, stated with the estimate: 60%; middle value at least 1.0-fold (0.02 log units) away from the limit.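

In this assay compound 4 gives > 300000 nM, which is a limit of the assay and not a number. Propyl in place of isopropyl on the nitrogen therefore leaves this position at the same limit, and the steps linking compound 4 to compound 2 and compound 3 cannot be read; the only readable step is an at least 1.1-fold higher number from compound 1 to compound 4 (0.05 log units; that floor lies within the scatter), which is a floor and not a measured size. With this result, the amino substituents larger than the methyl of compound 1 now include both a branched and a straight three-carbon chain, and the series gathers further at a single point: the limit of > 300000 nM in this assay, at which 3 of the 4 values shown sit.

Going by these compounds, whether isopropyl and propyl differ at all at this position stays open, as does how far the true values of compound 2, compound 3 and compound 4 lie from the limit. Only compound 1 has a true number, 265000 nM. A longer chain such as octyl, or a propyl chain ending in an amine, on the same nitrogen could show whether any change at this place brings the read-out to a true number.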